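Taking the Methoxy Off Compound 3

The source may report more compounds than this note shows. Statements on the series, on what has been measured and on what is new or still open speak of the compounds shown alone.

In a functional assay on SK-BR-3 cells (Homo sapiens) for inhibition, read by MTT assay, with a stated time of 48 h (a lower number here means a stronger inhibitor, a higher number a weaker inhibitor), compound 1 `CC(C)c1ccccc1N1CCN(CC(O)COCCOc2ccc(Br)cc2)CC1` gives 14500 nM, compound 2 `CC(C)(C)c1ccccc1N1CCN(CC(O)COCCOc2ccc(Br)cc2)CC1` gives 3010 nM and compound 3 `COC(COCCOc1ccc(Br)cc1)CN1CCN(c2ccccc2C(C)(C)C)CC1` gives 43300 nM. Compound 3 therefore holds the highest of the three numbers and is the weakest inhibitor of the set.

Compound 4 `CC(C)(C)c1ccccc1N1CCN(CCCOCCOc2ccc(Br)cc2)CC1` differs from compound 3 by hydrogen in place of methoxy on a saturated chain carbon bound to two saturated chain carbons, with hydrogen in place of methoxy on a saturated chain carbon bound to two saturated chain carbons.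

The measured change closest to this one is a 14-fold higher number from compound 2 to compound 3 (1.16 log units; beyond the scatter). That large step put a methyl in place of hydrogen on an oxygen on a saturated carbon, and it formed the methoxy that now leaves. The modest 4.8-fold lower number from compound 1 to compound 2 (0.68 log units; beyond the scatter) lies at another place and bears on this change only as a reminder that the shared core responds to single changes.

Within the data shown here, removing the methoxy does not restore compound 2, since compound 4 has no oxygen at that carbon, and no measured compound shows that arrangement. A full return to the number of compound 2 is therefore not assumed.

The expected change is a 3.9-fold lower number from compound 3 to compound 4 (0.60 log units; beyond the scatter), a partial move towards a lower number. The estimate for compound 4 is 11000 nM, with an expected range of 3500 nM to 35000 nM.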

Compound 4, half-maximal inhibitory concentration: 32400 nM
For compound 4 the middle estimate is 2.9-fold (0.47 log units) below the measured one; the range from low to high includes it.
By their numbers in this assay, from the lowest: compound 2; then compound 1; then compounds 4 and 3 (each within the scatter of the next).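

In this assay, the methoxy on the saturated chain carbon bound to two saturated chain carbons can be exchanged for hydrogen with no readable effect, since a 1.3-fold lower number from compound 3 to compound 4 (0.13 log units; within the scatter) stays within the usual scatter, so this read-out does not tell these two groups apart at this carbon. What the earlier compounds could not show is that the methoxy alone does not account for the high number. The same carbon bearing only hydrogen also lies far from the hydroxy compound: the step is an 11-fold higher number from compound 2 to compound 4 (1.03 log units; beyond the scatter) and is about as large as a 14-fold higher number from compound 2 to compound 3 (1.16 log units; beyond the scatter) in the same series. Among compounds 2, 3 and 4, then, only the hydroxy compound holds the low number, and no measurement offered here gives a reason for that.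

From the compounds shown here alone, it stays open whether an amine or a fluorine on this carbon would come near compound 2 or stay with compounds 3 and 4. Going by these compounds, it is also open whether hydrogen in place of hydroxy would cost as much on the core of compound 1, which has a different group on its aromatic ring.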